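The compounds below may be only part of what the source reports. "The series", "measured", "known", "first", "only" and "open" are said of these compounds alone.

Compound 1 `COc1ccccc1-c1cnc(C(=O)CCCCCCc2ccccc2)o1` is the weakest of the three measured compounds in an assay (Rattus norvegicus) for inhibition of Fatty-acid amide hydrolase 1 (Homo sapiens); a lower number here means a stronger inhibitor, a higher number a weaker inhibitor: compound 1 gives 400 nM, while compound 3 `COc1ccc(-c2cnc(C(=O)CCCCCCc3ccccc3)o2)cc1` gives 100 nM and compound 2 `N#Cc1cccc(-c2cnc(C(=O)CCCCCCc3ccccc3)o2)c1` gives 15 nM. The shared core carries a long phenyl-tipped chain on one side and a varying aromatic ring on the other, and only that ring differs among these compounds.

Compound 4 `O=C(CCCCCCc1ccccc1)c1ncc(-c2ccc(O)cc2)o1` changes this ring once more: 4-hydroxyphenyl in place of 2-methoxyphenyl on an aromatic carbon. The closest measured guide is the step of a 4.0-fold lower number from compound 1 to compound 3 (0.60 log units; beyond the scatter), which likewise moved the oxygen-bearing substituent from the 2-position to the 4-position. The step of a 27-fold lower number from compound 1 to compound 2 (1.43 log units; beyond the scatter) shows that a different 3-substituted ring gives a larger gain, and the step of a 6.7-fold higher number from compound 2 to compound 3 (0.82 log units; beyond the scatter) places the 4-methoxyphenyl between the two. Within the data shown here, no measured pair separates a hydroxyl from a methoxy group, so that part of the change is untested here.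

A modest improvement over compound 1 is therefore expected, roughly a 3.3-fold lower number from compound 1 to compound 4 (0.52 log units; beyond the scatter), and compound 4 is estimated at 120 nM, within 40 nM to 400 nM.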

Compound 4, inhibition constant: 140 nM
Compound 4: the middle estimate sits 1.2-fold (0.07 log units) below what was measured; the measured number falls inside the stated range.
By their numbers in this assay, from the lowest: compound 2; then compounds 3 and 4 (each within the scatter of the next); then compound 1.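

Among these compounds, replacing the methyl on the oxygen with hydrogen, a change no earlier pair could test, leaves the number within the scatter in this assay (a 1.4-fold higher number from compound 3 to compound 4 (0.15 log units; within the scatter)). So 4-hydroxyphenyl and 4-methoxyphenyl cannot be told apart here, even though only 4-hydroxyphenyl carries a hydrogen-bond donor. Against the other two rings, 4-hydroxyphenyl still improves on 2-methoxyphenyl (a 2.9-fold lower number from compound 1 to compound 4 (0.46 log units; beyond the scatter)) but falls well short of 3-cyanophenyl (a 9.3-fold higher number from compound 2 to compound 4 (0.97 log units; beyond the scatter)), and no information at hand explains these differences.

Compound 2 differs from compounds 3 and 4 in both the group and where it sits on the ring, so the compounds shown cannot say which of the two matters. On these data alone, how a carboxylic acid or an amine on this ring would behave also remains open.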